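A few compounds are considered here, and "the series" means these few. Any claim that something is new, unique, unknown or untested is made for them only; others in the source may bear on it.

Of the compounds shown here, three built on one shared core have been tested in a toxicity assay on HepG2 2.2.15 cells (Homo sapiens) for cytotoxicity, read by CellTiter-Glo; on this read-out lower numbers stand for higher toxicity in this test and higher numbers for lower toxicity in this test. Compound 1 `CC1(C)CC(=O)N(c2cnn3c2CN(C(=O)Nc2cc(F)c(F)c(F)c2)C(C2CC2)C3)C1` gives 115000 nM, compound 2 `O=C(Nc1cc(F)c(F)c(F)c1)N1Cc2c(-c3ccc(F)cc3)cnn2CC1C1CC1` gives 38500 nM, and compound 3 `O=C1CC(c2nccs2)CN1c1cnn2c1CN(C(=O)Nc1cc(F)c(F)c(F)c1)C(C1CC1)C2` gives 115000 nM. Compound 3 therefore stands level with compound 1, and the two together hold the highest number of the three.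

Compound 4 `O=C1CC(c2ccccn2)CN1c1cnn2c1CN(C(=O)Nc1cc(F)c(F)c(F)c1)C(C1CC1)C2` differs from compound 3 in one group: pyridin-2-yl in place of 1,3-thiazol-2-yl on a saturated ring carbon. Put simply, pyridin-2-yl sits in place of 1,3-thiazol-2-yl on a saturated ring carbon, two ring bonds from the ring nitrogen. Going by the values given here, no measured step changes this group alone, so the evidence is indirect. The closest guide is no change at the digits printed from compound 1 to compound 3 (within the scatter), a swap of 4,4-dimethyl-2-oxopyrrolidin-1-yl for 2-oxo-4-(1,3-thiazol-2-yl)pyrrolidin-1-yl. Among the compounds with values here, the only steps beyond the scatter involve the 4-fluorophenyl group: a 3.0-fold lower number from compound 1 to compound 2 (0.48 log units; beyond the scatter) and a 3.0-fold higher number from compound 2 to compound 3 (0.48 log units; beyond the scatter), both modest. Compound 4 has no such group and keeps the 2-oxopyrrolidin-1-yl unit of compound 3, so no step beyond the scatter is expected in this assay. The expected step is a 1.2-fold lower number from compound 3 to compound 4 (0.06 log units; within the scatter), which would stay within the scatter. For compound 4 the estimated value is 100000 nM, with an expected range from 55000 nM to 135000 nM.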

Compound 4, half-maximal cytotoxic concentration: 96200 nM
Compound 4: middle estimate off by 1.0-fold (0.02 log units), on the high side, within the range that was stated.
By their numbers in this assay, from the lowest: compound 2; then compounds 4, 1 and 3 (each within the scatter of the next).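

Replacing 1,3-thiazol-2-yl with pyridin-2-yl on the saturated ring carbon gives a 1.2-fold lower number from compound 3 to compound 4 (0.08 log units; within the scatter) in this assay and so swaps a five-membered aromatic ring for a six-membered one with no step beyond the scatter. Going by these compounds alone, the pyridin-2-yl version of the side group also reads like the one with two methyl groups on its ring, with a 1.2-fold lower number from compound 1 to compound 4 (0.08 log units; within the scatter) in the same test, so these three groups on the aromatic carbon of the shared core cannot be told apart here. Only compound 2 stands apart, with a 2.5-fold higher number from compound 2 to compound 4 (0.40 log units; beyond the scatter) as a modest step, so three compounds carrying a 2-oxopyrrolidin-1-yl unit now sit on one side of 4-fluorophenyl rather than two.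

No measurement shown offers an explanation for these results. Going by these compounds, it remains open how this assay would respond to an amine or a carboxylic acid on that saturated ring carbon, and whether a 2-oxopyrrolidin-1-yl unit with only hydrogens there would read like compounds 1, 3 and 4.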